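Methoxy for Methyl: Expected Growth Inhibition of Compound 4

This account rests on a few compounds, and the source may have more. Where it says the series, first, only, none or still open, it means among the compounds named here.

Compound 1 `Cc1ccc(NC(=S)N/N=C/c2cccs2)cc1`: 80600 nM
Compound 2 `S=C(N/N=C/c1cccs1)Nc1cccnc1`: 45900 nM
Compound 3 `C=CCNC(=S)N/N=C/c1cccs1`: reported only as a limit, > 100000 nM

All three measured compounds share a common core and differ only in the group attached at one end of it. They were tested in a functional assay on NCI-H460 cells (Homo sapiens) for inhibition, read by sulforhodamine B assay, with a stated time of 48 h; a higher number here means a weaker inhibitor of growth, a lower number a stronger inhibitor of growth. Of the two numbers reported, compound 1 gives 80600 nM, the higher one, with compound 2 at 45900 nM nearest to it; that gap lies within the scatter, so the two cannot be told apart. Compound 3 is known only as a limit of the limit of > 100000 nM in this assay, at which 1 of the 3 values shown sits, not as a number.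

Compound 4 `COc1ccc(NC(=S)N/N=C/c2cccs2)cc1` is the compound still to be measured. It differs from compound 1 by methoxy in place of methyl on an aromatic carbon. No pair among the measured compounds shows what such a swap does here, so there is nothing in the numbers shown to anchor a direction. The change is small, and the expectation is that the step from compound 1 to compound 4 stays within the scatter, so that compound 4 is estimated at a 1.2-fold lower number from compound 1 to compound 4 (0.06 log units; within the scatter). Compound 4 is therefore expected to give 70000 nM, with a range estimated from 30000 nM to 150000 nM.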

Compound 4, concentration for 50% growth inhibition: > 100000 nM
Compound 4 ended at the assay's limit; the forecaster's own chance of this, stated with the estimate: 25%; middle value at least 1.4-fold (0.15 log units) away from the limit.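

Going by these compounds alone, this is the first pair that isolates a single change on the aromatic ring: methoxy in place of methyl on an aromatic carbon of a six-membered aromatic ring of carbon only, para to a large group. In this assay, this swap gives an at least 1.2-fold higher number from compound 1 to compound 4 (0.09 log units; that floor lies within the scatter), so adding the oxygen here, and with it one hydrogen-bond acceptor, gives no sign of a lower number, meaning no sign of stronger growth inhibition, although the floor of the step does not rise beyond the scatter. How large the step really is cannot be read, since compound 4 is recorded only as a limit, and this result adds to the share of the series that stops there: the limit of > 100000 nM in this assay, at which 2 of the 4 values shown sit.

The compounds shown leave open whether another group at this same place, such as an amine, a carboxylic acid or a longer chain, would move the number down rather than up. Within the data shown here, with only this one pair, they also leave open whether methoxy in place of methyl would give a similar step on a different ring, such as the one carried by compound 2.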